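Replacing the 4-bromo-3-nitrophenyl group with 2,4-difluorophenyl

The compounds below may be only part of what the source reports. "The series", "measured", "known", "first", "only" and "open" are said of these compounds alone.

Measured compounds:
compound 1 `Nc1c(Br)cc(Br)cc1/C=C(\C(=O)c1ccc(Br)cc1)S(=O)(=O)c1ccc(Br)cc1`: 25000 nM
compound 2 `O=C(/C(=C\c1ccc(Br)c(O)c1)S(=O)(=O)c1ccc(Br)cc1)c1ccc(Br)cc1`: 50000 nM
compound 3 `O=C(/C(=C\c1ccc(Br)c([N+](=O)[O-])c1)S(=O)(=O)c1ccc(Br)cc1)c1ccc(Br)cc1`: 10000 nM

Of the compounds shown here, three have been tested in a functional assay on DU-145 cells (Homo sapiens) for inhibition, read by trypan blue exclusion, with a stated time of 96 h; on this read-out lower numbers stand for stronger inhibition of growth and higher numbers for weaker inhibition of growth. Compound 3 gives the lowest number of the three; compound 1 stands nearest with a 2.5-fold lower number from compound 1 to compound 3 (0.40 log units; beyond the scatter) in reverse, and compound 2 furthest, as a 5.0-fold lower number from compound 2 to compound 3 (0.70 log units; beyond the scatter) shows, so compound 3 is the strongest inhibitor of growth among the measured set. The change from compound 1 to compound 2 gives a 2.0-fold higher number from compound 1 to compound 2 (0.30 log units; within the scatter).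

Compound 4 `O=C(/C(=C\c1ccc(F)cc1F)S(=O)(=O)c1ccc(Br)cc1)c1ccc(Br)cc1` is not yet measured. It differs from compound 3 as follows: 2,4-difluorophenyl in place of 4-bromo-3-nitrophenyl on a double-bonded chain carbon bound to a double-bonded chain carbon. The measured steps show that the group on the double-bonded chain carbon matters: the nitro gave a 5.0-fold lower number from compound 2 to compound 3 (0.70 log units; beyond the scatter) against hydroxy, and the 2-amino-3,5-dibromophenyl fell between the two. The 2,4-difluorophenyl group brings no hydrogen-bond acceptors, unlike the nitro group it replaces, so a weaker inhibition of growth is expected, with a number in this assay nearer to compound 1 or compound 2. The estimated step is a 2.5-fold higher number from compound 3 to compound 4 (0.40 log units; beyond the scatter) for compound 4. Compound 4 is thus expected to give about 25000 nM, within a range from 8000 nM to 80000 nM.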

Compound 4, concentration for 50% growth inhibition: 7500 nM
The estimate for compound 4 lay 3.3-fold (0.52 log units) above the measured number; the whole stated range lies above it.
By their numbers in this assay, from the lowest: compounds 4 and 3 (each within the scatter of the next); then compounds 1 and 2 (each within the scatter of the next).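

In this assay, the step of a 1.3-fold lower number from compound 3 to compound 4 (0.12 log units; within the scatter) shows that 2,4-difluorophenyl and 4-bromo-3-nitrophenyl cannot be told apart at this position, so among these compounds a low number does not depend on a nitro group or on hydrogen-bond acceptors in the group that enters. The same group also separates clearly from the other two groups at this place, with a 6.7-fold lower number from compound 2 to compound 4 (0.82 log units; beyond the scatter) and a 3.3-fold lower number from compound 1 to compound 4 (0.52 log units; beyond the scatter), which means that two quite different groups now share the low end of the series while 4-bromo-3-hydroxyphenyl and 2-amino-3,5-dibromophenyl remain at the high end. Nothing measured here offers an explanation for this ordering of the groups.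

The compounds shown leave open whether the fluorine atoms contribute at all, since a plain phenyl group would be needed to test this, and how a methoxy group or a carboxylic acid on the ring would behave at this position. On these data alone, all four compounds also share the rest of the core, so it remains open whether these steps would hold if that part carried something other than its bromine atoms.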